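A few compounds are considered here, and "the series" means these few. Any claim that something is new, unique, unknown or untested is made for them only; others in the source may bear on it.

Notes on the series in a functional assay on SK-OV-3 cells (Homo sapiens) for inhibition, read by CCK-8 assay, with a stated time of 70 h; on this read-out lower numbers stand for stronger inhibition and higher numbers for weaker inhibition. Compound 1 (`O=C(O)c1cccc(COc2ccc(OCCOCCNC3CCCC3)cc2)c1`) gives > 100000 nM, which is a limit of the assay and not a number. Compound 2 (`COC(=O)c1ccccc1COc1ccc(OCCOCCNC2CCCC2)cc1`) gives > 100000 nM, again a limit. Within the data shown here, compound 3 (`CCOc1ccc(OCCOCCNC2CCCC2)cc1`) gives 90500 nM, the only true number so far, and the series as a whole sits at the limit of > 100000 nM in this assay, at which 2 of the 3 values shown sit.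

Compound 4 (`O=[N+]([O-])c1ccccc1COc1ccc(OCCOCCNC2CCCC2)cc1`) differs from compound 3 by one change: 2-nitrophenyl in place of methyl on a saturated chain carbon bound to an oxygen on an aromatic ring. Among the measured compounds shown here, two measured steps bear on this, both running the opposite way, from a substituted phenyl back to methyl at the same place: an at least 1.1-fold lower number from compound 1 to compound 3 (0.04 log units; that floor lies within the scatter) and an at least 1.1-fold lower number from compound 2 to compound 3 (0.04 log units; that floor lies within the scatter). Each is only a floor, and that floor lies within the scatter. The step that the two limits leave unreadable from compound 1 to compound 2 gives no size at all.

Compound 2 is the closest neighbour, with 2-(methoxycarbonyl)phenyl where compound 4 has 2-nitrophenyl. Compound 2 gives > 100000 nM as a limit, which offers no sign of a gain over methyl. No step beyond the scatter is therefore expected in this assay, and a report of a limit alone is quite possible. The expected step is a 1.0-fold higher number from compound 3 to compound 4 (0.02 log units; within the scatter). For compound 4 the estimated value is 95000 nM, with an expected range of 40000 nM to 150000 nM.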

Compound 4, half-maximal inhibitory concentration: 5370 nM
Beside the measured number, compound 4's estimate is 18-fold (1.25 log units) above it; the whole stated range lies above it.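

In this assay, the place on a saturated chain carbon bound to an oxygen on an aromatic ring proves able to carry a real gain: 2-nitrophenyl in place of methyl gives a 17-fold lower number from compound 3 to compound 4 (1.23 log units; beyond the scatter), where the earlier substituted phenyl groups showed nothing readable. Nitro in place of methoxycarbonyl on an aromatic carbon gives an at least 18-fold lower number from compound 2 to compound 4 (1.27 log units; beyond the scatter), so a phenyl ring at this place does not bring the gain by itself. 2-nitrophenyl in place of 3-carboxyphenyl gives an at least 18-fold lower number from compound 1 to compound 4 (1.27 log units; beyond the scatter), and this step and the one before it are floors, not sizes: the limit of > 100000 nM in this assay, at which 2 of the 4 values shown sit.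

Open, going by these compounds, is whether the gain belongs to the nitro group itself, since an amine or a nitrile in its place would separate that group from the phenyl ring that carries it. Also open, on these data alone, is whether a gain of this size holds beyond this one cell line, as all the values shown come from a single read-out.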